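The source may report more compounds than this note shows. Statements on the series, on what has been measured and on what is new or still open speak of the compounds shown alone.

The series shares one core, seen in compound 1 `CC[C@H](C)C(N)c1cc(C(F)(F)F)ccc1N1CCN(C(=O)CCc2ccc(Cl)cc2Cl)CC1`, compound 2 `CCC(C)[C@H](N)c1cc(C(F)(F)F)ccc1N1CCN(C(=O)CCc2ccc(OC)c(OC)c2Cl)CC1` and compound 3 `Cc1cccc(CCC(=O)N2CCN(c3ccc(C(F)(F)F)cc3[C@@H](N)CC(C)C)CC2)c1`; the three differ mainly in the aryl group on the saturated chain carbon two bonds along the chain from the carbonyl carbon. In an assay on HEK293 cells for displacement of a labelled ligand from Melanocortin receptor 4 (Homo sapiens) (on this read-out higher numbers stand for weaker inhibition and lower numbers for stronger inhibition), compound 1 gives 75 nM, compound 2 gives 2500 nM and compound 3 gives 2100 nM. Compound 3 thus stands second highest of the three numbers; its number and that of compound 2 lie within the scatter of each other, while compound 1 shows a lower number by a gap beyond the scatter. Compound 4 `CC(C)C[C@H](N)c1cc(C(F)(F)F)ccc1N1CCN(C(=O)CCc2csc3ccccc23)CC1` is not yet measured in this assay. It differs from compound 3 in one place: 1-benzothiophen-3-yl in place of 3-methylphenyl on a saturated chain carbon, two bonds along the chain from a carbonyl carbon. For the measured compounds named here, no measured pair isolates this change, so any expectation rests on the spread between compound 1 and compounds 2 and 3 at the same chain position. The step is expected to lead toward a lower number, of a size near the edge of the scatter or somewhat beyond, a 3.0-fold lower number from compound 3 to compound 4 (0.48 log units; beyond the scatter). Compound 4 is accordingly estimated at 700 nM, with a range from 150 nM to 3000 nM.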

Compound 4, inhibition constant: 2300 nM
Compound 4: the middle estimate sits 3.3-fold (0.52 log units) below what was measured; the range from low to high includes it.
By their numbers in this assay, from the lowest: compound 1; then compounds 3, 4 and 2 (each within the scatter of the next).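

In this assay, for the compounds shown here, 1-benzothiophen-3-yl in place of 3-methylphenyl on a saturated chain carbon, two bonds along the chain from a carbonyl carbon, gives a 1.1-fold higher number from compound 3 to compound 4 (0.04 log units; within the scatter), the first pair to isolate this position. On this pair, the entry of a five-membered aromatic ring with one hetero atom leaves the number within the scatter, so this change does not reproduce the lower number seen for compound 1. No supporting evidence bears on this result.

On these data alone, compound 1, at 75 nM, differs from compound 3 in more than one place, so it remains open whether its number belongs to its chlorinated aryl group or to another part of the structure. Also open, as far as these compounds go, is how a pyridyl or naphthyl group at this chain position would read in this assay.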